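This account rests on a few compounds, and the source may have more. Where it says the series, first, only, none or still open, it means among the compounds named here.

In a physicochemical assay for permeability, using PAMPA (a higher number here means that the compound crosses the layer faster, a lower number that the compound crosses the layer more slowly), compound 1 `Cc1ccccc1-c1nc(CN2CCC(C(=O)NCCCN3CC(C)(C)CC(C)(C)C3)CC2)c(C)o1` gives > 1390 10^-6 cm/s, which is a limit of the assay and not a number. Compound 2 `Cc1oc(-c2ccc(F)cc2)nc1CN1CCC(C(=O)NCCCN2C[C@H](C)C[C@H](C)C2)CC1` offers no comparison, since its entry reads "not determined" (no result reported). Within the data shown here, no step between measured compounds is therefore available, and the only measured reference is the limit of compound 1 at > 1390 10^-6 cm/s. Compound 3 `Cc1ccccc1-c1nc(CN2CCC(C(=O)NCCCN3[C@H](C)CCC[C@@H]3C)CC2)c(C)o1` keeps the core of compound 1 and changes in one place, on a saturated chain carbon, three bonds along the chain from an amide-type nitrogen, where 2,6-dimethylpiperidin-1-yl enters: a group of 8 heavy atoms (7 carbon, 1 nitrogen; one six-membered non-aromatic ring with 1 hetero atom) in place of a group of 10 heavy atoms (9 carbon, 1 nitrogen; one six-membered non-aromatic ring with 1 hetero atom), on a saturated chain carbon, three bonds along the chain from an amide-type nitrogen. Among the measured compounds shown here, with no measured step to guide the size of this change, no shift beyond the usual scatter is expected in this assay. The estimated step is an at least 1.1-fold lower number from compound 1 to compound 3 (0.06 log units; that floor lies within the scatter). For compound 3 the expected value is 1200 10^-6 cm/s, with an estimated range of 450 10^-6 cm/s to 2000 10^-6 cm/s.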

Compound 3, apparent permeability: 55.4 10^-6 cm/s
Compound 3: middle estimate off by 22-fold (1.34 log units), on the high side; measured number outside the range, below it.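

At this position, on a saturated chain carbon, three bonds along the chain from an amide-type nitrogen, the entry of 2,6-dimethylpiperidin-1-yl gives an at least 25-fold lower number from compound 1 to compound 3 (1.39 log units; beyond the scatter) in this assay. Among these compounds, this is the first step available, and it shows that a change in this one place can move the read-out well beyond the scatter. Compound 1 gives > 1390 10^-6 cm/s, which is a limit and not a number, so the step sets only a floor and its full size stays unknown: the limit of > 1390 10^-6 cm/s in this assay, at which 1 of the 3 values shown sits.

The compounds shown leave open whether a plain piperidine, a morpholine or an open-chain diethylamine here would stay close to compound 1 or fall towards compound 3. They also leave open whether a longer chain would alter the size of this step.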